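Unsaturating the Sulfur-Bound Propyl Chain of Compound 3

The source may hold more compounds than are shown below. What is called first, only, known or untested is meant among the compounds shown, and "the series" means these compounds.

Three compounds have been measured in a functional assay on MGC-803 cells (Homo sapiens) for inhibition, read by MTT assay, with a stated time of 72 h; a higher number here means a weaker inhibitor, a lower number a stronger inhibitor:
Compound 1 `C#CCSc1nc(Nc2cccc(OC)c2)c2ccncc2n1` gives 2070 nM.
Compound 2 `CCSc1nc(Nc2cccc(OC)c2)c2ccncc2n1` gives 590 nM.
Compound 3 `CCCSc1nc(Nc2cccc(OC)c2)c2ccncc2n1` gives 1950 nM.

Compound 3 stands second highest of the three numbers in this assay; its value and that of compound 1 lie within the scatter of each other, while compound 2 sits clearly lower, as a 3.3-fold higher number from compound 2 to compound 3 (0.52 log units; beyond the scatter) records. Compound 4 `C/C=C/Sc1nc(Nc2cccc(OC)c2)c2ccncc2n1` differs from compound 3 by prop-1-en-1-yl in place of propyl on a sulfur. For the measured compounds named here, two measured steps bear on this change. The step of a 1.1-fold lower number from compound 1 to compound 3 (0.03 log units; within the scatter) shows that exchanging a saturated chain end for an unsaturated one on the same sulfur-bound chain left the number essentially unchanged, whereas a 3.5-fold lower number from compound 1 to compound 2 (0.55 log units; beyond the scatter) and a 3.3-fold higher number from compound 2 to compound 3 (0.52 log units; beyond the scatter) show that it was the length of the chain, not its saturation, that moved the number. Compound 4 keeps the chain length of prop-1-en-1-yl and only adds a double bond, so the expected step for compound 4 is a 1.1-fold lower number from compound 3 to compound 4 (0.03 log units; within the scatter), nothing beyond the scatter. Compound 4 is therefore estimated to give 1800 nM in this assay, with a range from 700 nM to 4500 nM.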

Compound 4, half-maximal inhibitory concentration: 1030 nM
Estimate against measurement, compound 4: 1.7-fold (0.24 log units) above; the measured number falls inside the stated range.
By their numbers in this assay, from the lowest: compounds 2, 4, 3 and 1 (each within the scatter of the next, the first and the last beyond it).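

In this assay prop-1-en-1-yl is the first group on this sulfur that cannot be told apart from any other group shown, since all its steps lie within the scatter: propyl (a 1.9-fold lower number from compound 3 to compound 4 (0.28 log units; within the scatter)), ethyl (a 1.7-fold higher number from compound 2 to compound 4 (0.24 log units; within the scatter)) and propargyl (a 2.0-fold lower number from compound 1 to compound 4 (0.30 log units; within the scatter)). The earlier compounds shown here split into ethyl on one side and propyl and propargyl on the other, with steps beyond the scatter, but compound 4 falls within the scatter of both sides. The double bond in the propyl chain therefore produces no readable change at this position, and compound 4 does not settle on either side of that split.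

On these data alone, whether butyl, or a chain carrying an amine or a carboxylic acid, on this sulfur would move the number beyond the scatter remains open. Nothing available accounts for the differences among these compounds.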